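Methoxy for Methyl on a Shared Retinoid Core

A few compounds are considered here, and "the series" means these few. Any claim that something is new, unique, unknown or untested is made for them only; others in the source may bear on it.

Of the compounds shown here, two have so far been tested in an assay on isolated protein with retinoic acid receptor alpha (Homo sapiens) as the target; on this read-out higher numbers stand for larger maximal responses and lower numbers for smaller maximal responses. Compound 2 `Cc1cc2c(cc1C(=O)c1ccc3cc(C(=O)O)ccc3c1)C(C)(C)CCC2(C)C` gives 26%, the higher of the two numbers. Compound 1 `COc1c(C(=O)c2ccc3cc(C(=O)O)ccc3c2)ccc2c1C(C)(C)CCC2(C)C`, which carries its methoxy group elsewhere on the shared core, gives 0%, a gap beyond the usual scatter. Compound 3 `COc1cc2c(cc1C(=O)c1ccc3cc(C(=O)O)ccc3c1)C(C)(C)CCC2(C)C` is compound 2 with a single change: methoxy in place of methyl on an aromatic carbon. For the measured compounds named here, no measured pair shows this exact change, so the size of the step is open. Compound 3 is expected to reach about 15%, somewhere between 0% and 40%. That expectation means a modest downward step in this assay of a number 11 percentage points lower from compound 2 to compound 3 (beyond the scatter).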

Compound 3, largest response reached (reported as maximum), in percent of the reference or control that the assay uses: 23%
For compound 3 the middle estimate is 8 percentage points below the measured one; the measured number falls inside the stated range.
By their numbers in this assay, from the lowest: compound 1; then compounds 3 and 2 (each within the scatter of the next).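

Putting methoxy in place of methyl on this aromatic carbon gives a number 3 percentage points lower from compound 2 to compound 3 (within the scatter) in this assay. This first measured pair for the change shows that, on this read-out, the two groups cannot be told apart at this position, even though methoxy brings one more heavy atom and a hydrogen-bond acceptor. Nothing available explains this result. Going by these compounds, whether an amine or a longer chain on the same carbon would also read like compound 2 remains open.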